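The source may hold more compounds than are shown below. What is called first, only, known or untested is meant among the compounds shown, and "the series" means these compounds.

Compound 3 `COc1ccc(F)cc1CNCCCNc1ccnc2cc(Cc3ccc(F)cc3Cl)ccc12` gives 9.47 in a physicochemical assay for acid dissociation. For comparison, compound 1 `COc1ccc(F)cc1CNCCCNc1ccnc2cc(CC(C)C)ccc12` gives 9.47 and compound 2 `COc1ccc(F)cc1CNCCCNc1ccnc2cc(Oc3ccc(C(C)(C)C)cc3)ccc12` gives 9.28, so compound 3 stands level with compound 1 at the digits shown, with no change at the digits printed from compound 1 to compound 3 (within the scatter), and the other measured step is a number 0.19 log units higher from compound 2 to compound 3 (within the scatter). Compound 4 `COc1ccc(F)cc1CNCCCNc1ccnc2cc(-c3cccc4ccccc34)ccc12` differs from compound 3 by naphthalen-1-yl in place of 2-chloro-4-fluorobenzyl on an aromatic carbon. The steps already measured at this aromatic carbon, a number 0.19 log units lower from compound 1 to compound 2 (within the scatter) and no change at the digits printed from compound 1 to compound 3 (within the scatter), both stayed within the scatter, so no step beyond the scatter is expected for compound 4 in this assay, and the estimated step is a number 0.02 log units lower from compound 3 to compound 4 (within the scatter). Compound 4 is accordingly estimated at 9.45, with a range from 9.15 to 9.75.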

Compound 4, acid dissociation constant: 9.47
Estimate against measurement, compound 4: 0.02 log units below; low and high end bracket the measured number.
By their numbers in this assay, from the lowest: compounds 2, 1, 3 and 4 (each within the scatter of the next).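

With naphthalen-1-yl on this aromatic carbon, the record reads no change at the digits printed from compound 3 to compound 4 (within the scatter) and no change at the digits printed from compound 1 to compound 4 (within the scatter) and a number 0.19 log units higher from compound 2 to compound 4 (within the scatter) in this assay even though this group brings two six-membered aromatic rings of carbon only and no halogen. Across the four groups shown at this position, every printed step stays within the scatter. Nothing available explains this result. On these data alone, whether an amine or a carboxylic acid on this aromatic carbon would give a step beyond the scatter in this assay remains open.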